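Swapping the halophenyl of compound 3 for a hydroxyphenyl

A few compounds are considered here, and "the series" means these few. Any claim that something is new, unique, unknown or untested is made for them only; others in the source may bear on it.

Compound 1, `COc1cccc(/C=C2\NS(=O)(=O)c3ccccc3C2=O)c1`, sits at the limit of the assay: > 200000 nM.
Compound 2, `O=C1/C(=C/c2cccc(Br)c2)NS(=O)(=O)c2ccccc21`, also sits at the limit: > 200000 nM.
Compound 3, `O=C1/C(=C/c2ccc(Cl)cc2)NS(=O)(=O)c2ccccc21`, gives 250 nM.

In an assay for inhibition of alkaline phosphatase, tissue-nonspecific isozyme (Homo sapiens), read by spectrophotometry, with stated times of 10 min and 20 min (a lower number here means a stronger inhibitor, a higher number a weaker inhibitor), compound 3 is the only one of the three that returns a number; the other two values are limits, as the limit of > 200000 nM in this assay, at which 2 of the 3 values shown sit, shows. From compound 2 to compound 3 the step is an at least 800-fold lower number from compound 2 to compound 3 (2.90 log units; beyond the scatter), while the step that the two limits leave unreadable from compound 1 to compound 2 cannot be read.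

Compound 4, `O=C1/C(=C/c2cccc(O)c2)NS(=O)(=O)c2ccccc21`, differs from compound 3 by 3-hydroxyphenyl in place of 4-chlorophenyl on a double-bonded chain carbon bound to a double-bonded ring carbon. Within the data shown here, the one readable step bears on it: the 3-bromophenyl of compound 2 is at the limit, and only the 4-chlorophenyl of compound 3 gives a number. Compound 4 returns to a 3-substituted phenyl, now with hydroxy. Among the measured compounds shown here, whether hydroxy behaves as bromo did is unknown, since no compound shows it, so the estimate leans toward the limit but stays below it. Compound 4 is therefore expected to be a weaker inhibitor than compound 3, with an estimated step of a 160-fold higher number from compound 3 to compound 4 (2.20 log units; beyond the scatter). The expected value for compound 4 is 40000 nM, within a range from 2000 nM to 200000 nM.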

Compound 4, half-maximal inhibitory concentration: 3570 nM
Beside the measured number, compound 4's estimate is 11-fold (1.05 log units) above it; the measured number falls inside the stated range.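

In this assay, the 3-substituted phenyl turns out not to be tied to the limit of the assay: hydroxy in place of bromo gives an at least 56-fold lower number from compound 2 to compound 4 (1.74 log units; beyond the scatter), and hydrogen in place of the methyl on the oxygen gives an at least 56-fold lower number from compound 1 to compound 4 (1.74 log units; beyond the scatter), so a group at this place on the ring can decide whether any number is read at all. The 3-hydroxyphenyl still does not match the 4-chlorophenyl, with a 14-fold higher number from compound 3 to compound 4 (1.15 log units; beyond the scatter), which makes this change a large loss but not a complete one, and the step alters both the group and its place on the phenyl in a single move. The two gains over compounds 1 and 2 are open-ended, and their true size cannot be read: the limit of > 200000 nM in this assay, at which 2 of the 4 values shown sit.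

From the compounds shown here alone, what stays open is how much of the gap between compound 3 and compound 4 belongs to the group and how much to its place, a question that a 4-hydroxyphenyl or a 3-chlorophenyl would address directly. Going by these compounds, it is also open whether an amine or a carboxylic acid at this place on the phenyl would read more like hydroxy or more like bromo.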